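One Amide Swap on a Carbonyl Carbon

The source may hold more compounds than are shown below. What is called first, only, known or untested is meant among the compounds shown, and "the series" means these compounds.

Measured in a functional assay on Caco-2 cells (Homo sapiens) for antiproliferative activity, read by MTT assay, with a stated time of 48 h; on this read-out higher numbers stand for weaker inhibition and lower numbers for stronger inhibition:
Compound 1 `CCOc1ccc(NC(=O)c2ccc(C(CC)(CC)c3ccc(OCCC(O)(CC)CC)c(C)c3)n2CC)cc1`: > 50000 nM (a limit)
Compound 2 `CCOC(=O)CN(C)C(=O)c1ccc(C(CC)(CC)c2ccc(OCCC(O)(CC)CC)c(C)c2)n1CC`: 30300 nM

Among the measured compounds shown here, compound 2, at 30300 nM, holds the only actual number in this assay. The other reading, for compound 1, is a limit, as the limit of > 50000 nM in this assay, at which 1 of the 2 values shown sits, records. Compound 3 `CCC(C)C(CO)NC(=O)c1ccc(C(CC)(CC)c2ccc(OCCC(O)(CC)CC)c(C)c2)n1CC` carries (1-(hydroxymethyl)-2-methylbutyl)amino in place of ((ethoxycarbonyl)methyl)(methyl)amino on a carbonyl carbon. For the measured compounds named here, one measured step bears on this change, since it falls on a carbonyl carbon too: an at least 1.6-fold lower number from compound 1 to compound 2 (0.21 log units; that floor lies within the scatter). That single step shows no large move, so no shift beyond the scatter is expected in this assay, and no direction can be argued with confidence. The estimated change is a 1.2-fold lower number from compound 2 to compound 3 (0.08 log units; within the scatter). Compound 3 is expected to read 25000 nM, with an estimated range from 9000 nM to 60000 nM.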

Compound 3, half-maximal inhibitory concentration: > 50000 nM
Compound 3: no number, only a limit; the forecaster's own chance of this, stated with the estimate: 30%; at least 2.0-fold (0.30 log units) between middle value and limit.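

The swap of ((ethoxycarbonyl)methyl)(methyl)amino for (1-(hydroxymethyl)-2-methylbutyl)amino on the carbonyl carbon gives an at least 1.6-fold higher number from compound 2 to compound 3 (0.21 log units; that floor lies within the scatter). Compound 3 therefore adds a second amide, one without the 4-ethoxyphenyl group of compound 1, whose reading in this assay is a limit and not a number: the limit of > 50000 nM in this assay, at which 2 of the 3 values shown sit. The step between compound 1 and compound 3 cannot be read, so the two limits do not rank these groups.

Among the compounds shown here, compound 2 remains the only compound with a number, and whether any group on this carbonyl carbon can take the reading beyond the scatter from that number stays open. A carboxylic acid in place of the ethoxycarbonyl of compound 2, or a morpholine on the carbonyl carbon, would put that question to this position.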